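Hydroxy to Fluoro on a Fused Core: Cytotoxicity Outlook

This account rests on a few compounds, and the source may have more. Where it says the series, first, only, none or still open, it means among the compounds named here.

Measured compounds:
compound 1 `C=C1C(=O)[C@]23C[C@@]1(O)CC[C@H]2[C@@]12C=CC(=O)[C@](C)(C(=O)O1)[C@H]2[C@@H]3C(=O)OC` gives 90900 nM
compound 2 `C=C1C(=O)[C@]23C[C@@]1(O)CC[C@H]2[C@@]12C=CC(=O)[C@](C)(C(=O)O1)[C@H]2[C@@H]3C(=O)OCc1ccccc1` gives 23900 nM

Of the compounds shown here, two sharing one core have been tested in a functional assay on A549 cells (Homo sapiens) for cytotoxicity, read by MTT assay; a lower number here means a stronger inhibitor, a higher number a weaker inhibitor. Compound 2 has the lowest of the two numbers; its nearest neighbour, compound 1, sits a clear step higher. Among the compounds with values here, the only step measured so far, a 3.8-fold lower number from compound 1 to compound 2 (0.58 log units; beyond the scatter), concerns the ester end of the molecule and not the ring carbon changed here.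

Compound 3 `C=C1C(=O)[C@]23C[C@@]1(F)CC[C@H]2[C@@]12C=CC(=O)[C@](C)(C(=O)O1)[C@H]2[C@@H]3C(=O)OCc1ccccc1` differs from compound 2 in one place: fluoro in place of hydroxy on a saturated ring carbon. Within the data shown here, no measured pair in this set alters that position, so nothing in the data speaks directly to the size or direction of this change. Since the step from compound 1 to compound 2 touches a different part of the core, it offers no guide beyond showing that single changes on this scaffold can shift this assay by a modest amount. The expectation for compound 3 is therefore a step of about a 1.2-fold lower number from compound 2 to compound 3 (0.08 log units; within the scatter) in this assay, which is none beyond the scatter. Compound 3 is estimated at 20000 nM, with a range from 6000 nM to 65000 nM.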

Compound 3, half-maximal inhibitory concentration: 64400 nM
For compound 3 the middle estimate is 3.2-fold (0.51 log units) below the measured one, and the stated range covers the measured number.
By their numbers in this assay, from the lowest: compound 2; then compounds 3 and 1 (each within the scatter of the next).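

In this assay, this saturated ring carbon of the five-membered ring now has a measured change: fluoro in place of hydroxy, with the ester end of compound 2 held fixed, gives a 2.7-fold higher number from compound 2 to compound 3 (0.43 log units; beyond the scatter). The position is therefore not silent in this assay, and the exchange, which removes the hydrogen-bond donor and hydrogen-bond acceptor counted for the hydroxy, moves the result toward weaker inhibition, the opposite direction from the ester-end change in a 3.8-fold lower number from compound 1 to compound 2 (0.58 log units; beyond the scatter). No measurement available here accounts for the rise in the number at this ring carbon.

As far as these compounds go, with a single replacement at this carbon, it remains open whether the hydroxy group itself is favourable here or whether fluoro in particular is unfavourable, a question that a methoxy group, an amine or a plain hydrogen at the same place could help to settle. From the compounds shown here alone, it also remains open whether the same exchange would give a step of similar size and direction on the methyl ester of compound 1 , where the ester end is different.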